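The compounds below may be only part of what the source reports. "The series", "measured", "known", "first", "only" and "open" are said of these compounds alone.

In a functional assay on MCF7 cells (Homo sapiens) for inhibition, read by MTT assay, with a stated time of 72 h (a higher number here means a weaker inhibitor, a lower number a stronger inhibitor), three compounds that share one core have been measured. Compound 1 (`COc1cc(NC(C)CCCNC(=O)Nc2cccc(F)c2)c2ncccc2c1`) gives 18000 nM, compound 2 (`COc1cc(NC(C)CCCNC(=O)NNC(=O)Nc2ccc(Cl)cc2)c2ncccc2c1`) gives 180 nM, and compound 3 (`COc1cc(NC(C)CCCNC(=O)NNC(=O)Nc2cccc(C(F)(F)F)c2)c2ncccc2c1`) gives 190 nM. Compound 3 therefore stands level with compound 2, within the scatter, and far from compound 1.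

The next structure, compound 4 (`COc1cc(NC(C)CCCNC(=O)NNC(=O)Nc2ccc(O)cc2)c2ncccc2c1`), has 4-hydroxyphenyl in place of 3-(trifluoromethyl)phenyl on an amide-type nitrogen. Among the compounds with values here, two measured steps bear on this change. The large one, a 100-fold lower number from compound 1 to compound 2 (2.00 log units; beyond the scatter), replaced more than a phenyl group, so it is only a weak guide here. The closer guide is a 1.1-fold higher number from compound 2 to compound 3 (0.02 log units; within the scatter), where one substituted phenyl group replaced another. Within the data shown here, no measured compound tests a 4-hydroxyphenyl group directly, so some uncertainty remains.

A small step toward a higher number is expected in this assay. The estimated change is a 1.8-fold higher number from compound 3 to compound 4 (0.27 log units; within the scatter). Compound 4 is expected at about 350 nM, with an estimated range of 120 nM to 1200 nM.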

Compound 4, half-maximal inhibitory concentration: 2600 nM
Estimate against measurement, compound 4: 7.4-fold (0.87 log units) below; measured number outside the range, above it.
By their numbers in this assay, from the lowest: compounds 2 and 3 (each within the scatter of the next); then compound 4; then compound 1.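

In this assay, this position on the amide-type nitrogen proves sensitive to the choice of substituted phenyl group: replacing trifluoromethyl-bearing phenyl with 4-hydroxyphenyl gives a 14-fold higher number from compound 3 to compound 4 (1.14 log units; beyond the scatter), and hydroxy in place of chloro on an aromatic carbon gives a 14-fold higher number from compound 2 to compound 4 (1.16 log units; beyond the scatter), so a single substituent can matter greatly here. The longer carbamoyl-containing side chain still keeps an advantage with 4-hydroxyphenyl, at a 6.9-fold lower number from compound 1 to compound 4 (0.84 log units; beyond the scatter), but this is much smaller than a 100-fold lower number from compound 1 to compound 2 (2.00 log units; beyond the scatter). No measurement shown explains why the hydroxy compound loses so much.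

The compounds shown leave open whether a 4-methoxyphenyl or 4-aminophenyl group would stay close to compound 2 or fall toward compound 4. They also leave open how a 3-hydroxyphenyl group would behave on the same nitrogen.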